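A few compounds are considered here, and "the series" means these few. Any claim that something is new, unique, unknown or untested is made for them only; others in the source may bear on it.

Measured compounds in a physicochemical assay for solubility, at pH 6.9; a higher number here means a more soluble compound, a lower number a less soluble compound:
compound 1 `O=C(CN1CCN(c2cc3c(cc2F)c(=O)c(C(=O)O)cn3C2CC2)CC1)Nc1ccc(C(=O)/C=C/c2ccccc2)cc1` gives 2.73 ug/mL;
compound 2 `O=C(CN1CCN(c2cc3c(cc2F)c(=O)c(C(=O)O)cn3C2CC2)CC1)Nc1ccc(C(=O)/C=C/c2ccc(Cl)cc2)cc1` gives 2.77 ug/mL.

In this assay compound 2 stands highest of the two numbers, but the gap to compound 1 is within the scatter, so the two read as the same. Going by the values given here, the single measured step, a 1.0-fold higher number from compound 1 to compound 2 (0.01 log units; within the scatter), was a change at the aromatic carbon para to a large group and moved nothing beyond the scatter.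

Compound 3 `COc1ccc(/C=C/C(=O)c2ccc(NC(=O)CN3CCN(c4cc5c(cc4F)c(=O)c(C(=O)O)cn5C4CC4)CC3)cc2)cc1` differs from compound 2 by methoxy in place of chloro on an aromatic carbon. Among the compounds with values here, no measured pair covers a methoxy entering at this position; the only step that bears on the site, from compound 1 to compound 2, was flat. The expectation therefore is no change beyond the scatter, a step of a 1.2-fold higher number from compound 2 to compound 3 (0.06 log units; within the scatter). Compound 3 is expected at 3.2 ug/mL, with a range from 1.5 ug/mL to 7 ug/mL.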

Compound 3, solubility: 2.98 ug/mL
The estimate for compound 3 lay 1.1-fold (0.03 log units) above the measured number; the measured number falls inside the stated range.
By their numbers in this assay, from the lowest: compounds 1, 2 and 3 (each within the scatter of the next).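

In this assay the aromatic carbon para to a large group now takes a third group with no step beyond the scatter: methoxy in place of chloro gives (a 1.1-fold higher number from compound 2 to compound 3 (0.03 log units; within the scatter)), and methoxy in place of hydrogen gives (a 1.1-fold higher number from compound 1 to compound 3 (0.04 log units; within the scatter)). The earlier pair covered chloro alone, whereas this change brings in an oxygen and a hydrogen-bond acceptor, and the read-out still does not separate the 4-methoxyphenyl compound from the 4-chlorophenyl compound or the unsubstituted phenyl compound. Nothing available here offers an explanation for this flat result.

As far as these compounds go, whether an amine or a carboxylic acid at this same carbon would also stay within the scatter remains open. So does the effect of any change away from this site, whether on the ethenyl link or on the shared core.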